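A few compounds are considered here, and "the series" means these few. Any claim that something is new, unique, unknown or untested is made for them only; others in the source may bear on it.

Two amides on a shared core have been measured in a functional assay on U-87MG ATCC cells for cytotoxicity against U-87 MG (Homo sapiens), read by MTT assay, with a stated time of 72 h; a lower number here means a stronger inhibitor, a higher number a weaker inhibitor. Compound 1 `COc1ccc2nc(NC(=O)c3cn(-c4ccccc4)nc3-c3ccccc3)sc2c1` gives 40600 nM. Among the measured compounds shown here, compound 2 `COc1ccc(-c2nn(-c3ccccc3)cc2C(=O)Nc2nc3ccccc3s2)cc1` gives 11500 nM, the lowest of the two numbers; the gap to compound 1 lies beyond the scatter, but as the two structures differ in more than one place no single step is drawn between them. Compound 3 `COc1ccc(-c2nn(-c3ccccc3)cc2C(=O)Nc2nc3ccc(OC)cc3s2)cc1` has not yet been measured. It differs from compound 2 by methoxy in place of hydrogen on an aromatic carbon, so that the methoxy groups of compound 1 and of compound 2 are both present. For the measured compounds named here, no measured step in this assay covers this change alone. Compound 3 is expected to stay close to compound 2, the estimated step of a 1.0-fold higher number from compound 2 to compound 3 (0.02 log units; within the scatter) lying within the scatter and without a firm direction. For compound 3 the estimate in this assay is 12000 nM, within the range 5000 nM to 32000 nM.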

Compound 3, half-maximal inhibitory concentration: 5890 nM
Compound 3: middle estimate off by 2.0-fold (0.31 log units), on the high side, and the stated range covers the measured number.
By their numbers in this assay, from the lowest: compounds 3 and 2 (each within the scatter of the next); then compound 1.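

Placing methoxy on the six-membered aromatic ring of the fused system, turning 1,3-benzothiazol-2-yl into 6-methoxy-1,3-benzothiazol-2-yl, gives a 2.0-fold lower number from compound 2 to compound 3 (0.29 log units; within the scatter), so this position tolerates the group but the step shows no firm gain. The clearer effect appears on the other side of the amide: with the 6-methoxy group held in place, adding the methoxy that compound 2 also carries gives a 6.9-fold lower number from compound 1 to compound 3 (0.84 log units; beyond the scatter), a modest step, and the two methoxy groups are compatible on one molecule. Nothing measured here accounts for either step.

The compounds shown leave open what hydrogen at both places would give, and so whether the two methoxy groups add up. They also leave open whether an amine, a carboxylic acid or a longer chain such as ethoxy at the 6-methoxy position would separate from compound 2.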